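Phenyl for thiophen-2-yl at the assay limit

The source may hold more compounds than are shown below. What is called first, only, known or untested is meant among the compounds shown, and "the series" means these compounds.

In an ADME assay on MRC5 cells (Homo sapiens), read by MTT assay, with a stated time of 72 h (on this read-out higher numbers stand for weaker inhibition and lower numbers for stronger inhibition), compound 3 (`COc1nc(N)nc2c1c(-c1cccs1)cn2[C@@H]1O[C@H](CO)[C@@H](O)[C@H]1O`) gives > 100000 nM as a limit of the assay and not a number. Compound 2 (`COc1nc(N)nc2c1c(-c1ccoc1)cn2[C@@H]1O[C@H](CO)[C@@H](O)[C@H]1O`) gives > 100000 nM as a limit as well. Compound 1 (`COc1ncnc2c1c(-c1ccccc1)cn2[C@@H]1O[C@H](CO)[C@@H](O)[C@H]1O`) also gives > 100000 nM as a limit. The evidence so far is thus the limit of > 100000 nM in this assay, at which 3 of the 3 values shown sit, and it holds no number.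

Compound 4 (`COc1nc(N)nc2c1c(-c1ccccc1)cn2[C@@H]1O[C@H](CO)[C@@H](O)[C@H]1O`) carries phenyl in place of thiophen-2-yl on an aromatic carbon of the shared core. Going by the values given here, the one measured step that bears on this change is a step that the two limits leave unreadable from compound 2 to compound 3 and it gives no size to build on. No step beyond the usual scatter is therefore expected in this assay and a further reading at the limit seems likely. The expected change is a number no higher from compound 3 to compound 4 (the limit leaves the size open) as an estimate only. The estimate for compound 4 is 100000 nM with an expected range from 40000 nM to 150000 nM in this assay as the read-out.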

Compound 4, half-maximal inhibitory concentration: > 100000 nM
Compound 4: a limit, no number; the forecaster's own chance of this, stated with the estimate: 80%; the middle value lies on the limit itself.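

In this assay compound 4 gives > 100000 nM, a limit of the assay and not a number, so its steps from compound 1, compound 2 and compound 3 cannot be read. The compounds shown leave open whether phenyl, thiophen-2-yl, furan-3-yl or amino changes the read-out at all, the evidence being only this: the limit of > 100000 nM in this assay, at which 4 of the 4 values shown sit.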